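Adding an Ethoxy Group to a Kinase Inhibitor Amide

This account rests on a few compounds, and the source may have more. Where it says the series, first, only, none or still open, it means among the compounds named here.

Of the compounds shown here, three have been measured in an assay on isolated protein for inhibition of Rho-associated protein kinase 1 (Homo sapiens), read by scintillation counting, radiometric assay and 33P incorporation, with a stated time of 40 min, in the presence of a further agent that is not named here; a higher number here means a weaker inhibitor, a lower number a stronger inhibitor.
Compound 1, `CN(C)c1ccc(C(=O)Nc2cccc(NC(=O)COc3ccc4c(c3)NC(=O)CC4)c2)cc1`: in this assay compound 1 reaches only the assay limit of > 10000 nM.
Compound 2, `COc1ccc(OCC(=O)Nc2cccc(NC(=O)c3ccc(N(C)C)cc3)c2)cc1F`: compound 2 gives 1820 nM.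
Compound 3, `O=C(COc1ccc2c(=O)ccoc2c1)Nc1cccc(NC(=O)c2ccccc2)c1`: compound 3 gives 120 nM.

Compound 3 thus has the lowest number of the two actual values, with compound 2 at a higher number beyond the scatter; compound 1 is a limit only (the limit of > 10000 nM in this assay, at which 1 of the 3 values shown sits).

Compound 4, `CCOc1ccc(C(=O)Nc2cccc(NC(=O)COc3ccc4c(=O)ccoc4c3)c2)cc1`, differs from compound 3 by ethoxy in place of hydrogen on an aromatic carbon. For the measured compounds named here, the one measured step, an at least 5.4-fold lower number from compound 1 to compound 2 (0.73 log units; beyond the scatter), changes the group on the oxygen at the other end of the shared core, so it says nothing about this change. Going by the values given here, with no step bearing on it, no change beyond the scatter is expected: compound 4 is estimated at 130 nM (range 40 nM to 450 nM), a step of a 1.1-fold higher number from compound 3 to compound 4 (0.03 log units; within the scatter).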

Compound 4, half-maximal inhibitory concentration: 17 nM
For compound 4 the middle estimate is 7.6-fold (0.88 log units) above the measured one; the measured number lies below the stated range.
By their numbers in this assay, from the lowest: compound 4; then compound 3; then compound 2. At a limit, above all of these: compound 1.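

The step from hydrogen to ethoxy, on an aromatic carbon para to a large group, gives a 7.1-fold lower number from compound 3 to compound 4 (0.85 log units; beyond the scatter). For the compounds shown here, this is the first measured change at this end of the shared core, and it shows that this position responds to a substituent, with the lower number meaning a stronger inhibitor. Nothing measured here accounts for this gain. From the compounds shown here alone, whether the oxygen or the ethyl part of ethoxy matters remains open, as does how a propoxy chain, an amine or a carboxylic acid at this place would compare.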